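The compounds below may be only part of what the source reports. "The series", "measured", "known", "first", "only" and "open" are said of these compounds alone.

Compound 1 `O=C(CSc1nc2ccccc2[nH]1)c1ccc([N+](=O)[O-])cc1` is the weakest point of reference here: in a functional assay on HT-29 cells (Homo sapiens) for inhibition, read by WST assay, with a stated time of 48 h (on this read-out lower numbers stand for stronger inhibition and higher numbers for weaker inhibition), compound 1 gives 57000 nM, the highest of the three numbers measured. Compound 2 `O=C(CSc1nc2ccccc2[nH]1)c1ccc(Br)cc1` gives 43000 nM, and the step of a 1.3-fold lower number from compound 1 to compound 2 (0.12 log units; within the scatter) shows that bromo in place of nitro on an aromatic carbon leaves the number essentially where it was. Compound 3 `COc1ccc(C(=O)CSc2nc3ccccc3[nH]2)c(OC)c1OC`, which carries three methoxy groups on the same ring, gives 18800 nM, the lowest number of the set and beyond the scatter from compound 1.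

Compound 4 `COc1ccc(C(=O)CSc2nc3ccccc3[nH]2)cc1` has not yet been measured. It differs from compound 1 as follows: methoxy in place of nitro on an aromatic carbon. Within the data shown here, only the step from compound 1 to compound 2 bears directly on a swap at this aromatic carbon, and it was within the scatter; the methoxy-bearing compound 3 hints that the number may come down somewhat. Compound 4 is therefore expected to give 32000 nM, within a range of 12000 nM to 80000 nM, a step of a 1.8-fold lower number from compound 1 to compound 4 (0.25 log units; within the scatter) that is expected to be modest.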

Compound 4, half-maximal inhibitory concentration: 25200 nM
The estimate for compound 4 lay 1.3-fold (0.10 log units) above the measured number; the measured number falls inside the stated range.
By their numbers in this assay, from the lowest: compounds 3, 4, 2 and 1 (each within the scatter of the next, the first and the last beyond it).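

Among these compounds, at this aromatic carbon, para to a large group, the swap of nitro for methoxy is the first single change to pass beyond the scatter in this assay, with a 2.3-fold lower number from compound 1 to compound 4 (0.35 log units; beyond the scatter). The swap of bromo for methoxy does not separate the two groups, with a 1.7-fold lower number from compound 2 to compound 4 (0.23 log units; within the scatter), and since the swap of nitro for bromo also stayed within the scatter, only nitro and methoxy can be told apart at this carbon. Nothing measured here accounts for that difference.

From the compounds shown here alone, it remains open whether an amine, a hydroxyl or a carboxylic acid at this carbon would give a number distinct from those of methoxy and bromo. Going by these compounds, it is also open whether a longer chain such as ethoxy would take the number beyond the scatter from compound 4.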